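Swapping chloro for cyano on the aryl piperazine

The compounds below may be only part of what the source reports. "The series", "measured", "known", "first", "only" and "open" are said of these compounds alone.

Measured compounds:
- compound 1, `Nc1ccccc1NC(=O)c1ccc(CSC(=S)N2CCN(c3ccc(Cl)cc3)CC2)cc1`, gives 15% in a functional assay on MGC-803 cells (Homo sapiens) for antiproliferative activity, read by CCK-8 assay, with a stated time of 72 h, tested at 2 uM; on this read-out lower numbers stand for a weaker effect and higher numbers for a stronger effect at the one concentration tested
- compound 2, `Nc1ccccc1NC(=O)c1ccc(CSC(=S)N2CCCc3ccccc32)cc1`, gives 38.5%
- compound 3, `CC1CCCCN1C(=S)SCc1ccc(C(=O)Nc2ccccc2N)cc1`, gives 64.4%

Compound 1 stands lowest of the three numbers. Its nearest neighbour is compound 2, whose value lies beyond the scatter above it, and compound 3 lies further above still. Among the compounds with values here, the one step between measured compounds that differ in a single place is a number 25.9 percentage points higher from compound 2 to compound 3 (beyond the scatter), and it concerns the amine attached to the thiocarbonyl carbon, not the aryl ring on the piperazine.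

Compound 4, `N#Cc1ccc(N2CCN(C(=S)SCc3ccc(C(=O)Nc4ccccc4N)cc3)CC2)cc1`, differs from compound 1 only in that ring: cyano in place of chloro on an aromatic carbon. No measured step touches this position, so nothing shown tells whether the change matters. The estimate therefore stays close to compound 1, with the wide range that such a gap in evidence demands. The expected step of a number 5 percentage points higher from compound 1 to compound 4 (within the scatter) is not beyond the scatter. Compound 4 is estimated at 20%, between 5% and 45%.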

Compound 4, a percentage reported as inhibition, at one concentration (the size of the read-out at that concentration, not a potency): 34.5%
Compound 4: middle estimate off by 14.5 percentage points, on the low side, and the stated range covers the measured number.
By their numbers in this assay, from the lowest: compound 1; then compounds 4 and 2 (each within the scatter of the next); then compound 3.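

The change from chloro to cyano on the aromatic ring brings a number 19.5 percentage points higher from compound 1 to compound 4 (beyond the scatter), so in this assay this position responds to what is placed on it. The earlier compounds shown here showed a change in the read-out only when the amine on the thiocarbonyl carbon was exchanged; this step shows that a swap of one small ring substituent, with the piperazine and the rest of the molecule kept, can also move the number beyond the scatter. No available data explain why this swap has that effect.

Going by these compounds, only chloro and cyano can be compared at this position, so it remains open how an amine, a methoxy group or a carboxylic acid would behave there. A bare hydrogen in the same place would show whether either group is needed at all.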